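Compound 3: allyl in place of cyclohexyl

A few compounds are considered here, and "the series" means these few. Any claim that something is new, unique, unknown or untested is made for them only; others in the source may bear on it.

compound 1 `O=C1Nc2ccccc2/C1=N/NC(=S)Nc1ccccc1` gives 1470 nM
compound 2 `O=C1Nc2ccccc2/C1=N/NC(=S)NC1CCCCC1` gives 4380 nM

In a functional assay on KB-V1 cells (Homo sapiens) for cytotoxicity, read by MTT assay, with a stated time of 72 h (on this read-out higher numbers stand for weaker inhibition and lower numbers for stronger inhibition), compound 2 holds the higher of the two numbers at 4380 nM in this short series. The change leading to compound 3 `C=CCNC(=S)N/N=C1\C(=O)Nc2ccccc21` is allyl in place of cyclohexyl on an amide-type nitrogen. For the measured compounds named here, the one measured step bearing on it is a 3.0-fold higher number from compound 1 to compound 2 (0.47 log units; beyond the scatter) at that same place, modest and beyond the scatter. Going by the values given here, no measured compound carries allyl, so a step no larger than that one is expected, towards a slightly lower number and possibly within the scatter. The expected change is a 1.3-fold lower number from compound 2 to compound 3 (0.10 log units; within the scatter) by this estimate. Compound 3 is estimated at 3500 nM with an expected range of 1300 nM to 9000 nM in this read-out.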

Compound 3, half-maximal inhibitory concentration: 20700 nM
Compound 3: the middle estimate sits 5.9-fold (0.77 log units) below what was measured, outside the stated range (above it).
By their numbers in this assay, from the lowest: compound 1; then compound 2; then compound 3.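

In this assay, allyl on this amide-type nitrogen gives a 4.7-fold higher number from compound 2 to compound 3 (0.67 log units; beyond the scatter) and, as a large step, a 14-fold higher number from compound 1 to compound 3 (1.15 log units; beyond the scatter). Across these three compounds, the two with a ring at this place hold lower numbers than the ring-free allyl compound, and none goes against this order. Nothing available explains the step.

As far as these compounds go, it remains open whether the ring itself, the heavy-atom count or the double bond of allyl tracks with the change. A saturated propyl chain, a longer hexyl chain and a benzyl group would help separate these readings.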